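A few compounds are considered here, and "the series" means these few. Any claim that something is new, unique, unknown or untested is made for them only; others in the source may bear on it.

In a functional assay on SF-295 cells (Homo sapiens) (a lower number here means a stronger inhibitor of growth, a higher number a weaker inhibitor of growth), three closely related compounds have been measured. Compound 1 (`Cc1cc(C)c2c(O)cc(-c3ccc(Cl)cc3)nc2n1`) gives 16200 nM, and compound 2 (`Oc1cc(-c2ccc(Cl)cc2)nc2ncccc12`) gives 40700 nM. Compound 3 (`Cc1ccnc2nc(-c3ccc(F)cc3)cc(O)c12`) gives 79400 nM, which is within the scatter of compound 2 and a weaker inhibitor of growth than compound 1, beyond the scatter. Compound 4 (`Cc1ccnc2nc(-c3ccc(Cl)cc3)cc(O)c12`) is not yet measured. It differs from compound 3 by chloro in place of fluoro on an aromatic carbon. Going by the values given here, no measured pair isolates this change, so the expectation is loose. It rests on the two chloro compounds, compound 1 at 16200 nM and compound 2 at 40700 nM. A modest gain is expected, an estimated 2.5-fold lower number from compound 3 to compound 4 (0.39 log units; beyond the scatter). For compound 4 the estimated value is 32000 nM, with an expected range of 13000 nM to 75000 nM.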

Compound 4, concentration for 50% growth inhibition: 5370 nM
For compound 4 the middle estimate is 6.0-fold (0.78 log units) above the measured one; the whole stated range lies above it.
By their numbers in this assay, from the lowest: compound 4; then compound 1; then compounds 2 and 3 (each within the scatter of the next).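

In this assay, going by these compounds alone, the first measured swap at this place, para to a large group, shows that chloro in place of fluoro is a large step (a 15-fold lower number from compound 3 to compound 4 (1.17 log units; beyond the scatter)). The methyl groups do not act additively: adding one to compound 2 strengthens growth inhibition (a 7.6-fold lower number from compound 2 to compound 4 (0.88 log units; beyond the scatter)), while removing one from compound 1 also strengthens it (a 3.0-fold lower number from compound 1 to compound 4 (0.48 log units; beyond the scatter)). Nothing measured here explains these steps.

As far as these compounds go, whether bromo or methoxy at this place would match chloro stays open. So does whether the chloro gain holds on the cores of compound 1 and compound 2.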